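A few compounds are considered here, and "the series" means these few. Any claim that something is new, unique, unknown or untested is made for them only; others in the source may bear on it.

The series is followed in a functional assay on MCF7 cells (Homo sapiens) for inhibition, with a stated time of 48 h; a higher number here means a weaker inhibitor of growth, a lower number a stronger inhibitor of growth. Compound 1 `Nc1ncnc2c1cnn2-c1ccc(C(F)(F)F)cc1` carries no result there: for compound 1 the entry reads "not determined" (no result reported). Compound 2 `Cc1ccc(-n2ncc3c(N)ncnc32)cc1` likewise stands without a single number in this assay, its entry being "not determined" (no result reported). Among the compounds with values here, compound 3 `N#Cc1cnn(-c2ccc(C(F)(F)F)cc2)c1N` is the only compound with a reported result, and that result is a limit of this assay: compound 3 gives > 150000 nM. Within the data shown here, the whole measured record therefore consists of one limit, (the limit of > 150000 nM in this assay, at which 1 of the 3 values shown sits), and no step between measured compounds can be drawn, so no measured size of step is available as a reference.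

Compound 4 `COC(=O)CNC(=O)c1ccc(-n2ncc3c(N)ncnc32)cc1` has yet to be measured. It differs from compound 2 by ((methoxycarbonyl)methyl)carbamoyl in place of methyl on an aromatic carbon. With no step shown, the direction of the change in this assay cannot be read from the data; the one reported value in the set is a limit, which leaves a weak result as the more likely outcome. Compound 4 is expected in this assay at about 50000 nM, estimated to fall between 5000 nM and 150000 nM, with a substantial chance that only a limit is reported.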

Compound 4, concentration for 50% growth inhibition: > 150000 nM
Compound 4 was reported as a limit; the forecaster's own chance of this, stated with the estimate: 50%; middle value at least 3.0-fold (0.47 log units) away from the limit.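

In this assay compound 4 gives > 150000 nM, a limit of the assay. Within the data shown here, compound 2 has no single number there, so no step between compound 2 and compound 4 can be read. The compounds shown leave open how any change on the shared core affects growth inhibition.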